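The compounds below may be only part of what the source reports. "The series", "measured", "known", "first", "only" and "open" are said of these compounds alone.

Measured so far in this series:

compound 2 `CN(C)c1ccc(/C=N/n2c(S)nnc2-c2cnccn2)cc1`: 14000 nM
compound 1 `CCOc1ccc(/C=N/n2c(S)nnc2-c2cnccn2)cc1OC`: 58800 nM
compound 3 `Oc1ccc2ccccc2c1/C=N/n1c(S)nnc1-c1cnccn1`: 69200 nM

The three compounds share one core and differ only in the aryl part attached to it. In a functional assay, with a stated time of 30 min (on this read-out higher numbers stand for weaker inhibition and lower numbers for stronger inhibition), compound 2 gives the lowest number of the three. Compound 1 sits higher at 58800 nM, and compound 3 higher still at 69200 nM; both gaps to compound 2 lie beyond the scatter, so compound 2 is the strongest inhibitor among the measured ones.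

Compound 4 `N#Cc1ccc(/C=N/n2c(S)nnc2-c2cnccn2)cc1` is not yet measured. It differs from compound 2 in one place: cyano in place of dimethylamino on an aromatic carbon. Among the compounds with values here, no pair of measured compounds shows this exchange, so its effect has to be guessed. The two measured compounds that lack dimethylamino, compound 1 and compound 3, both give clearly higher numbers than compound 2. A moderate weakening is therefore expected, with the step from compound 2 to compound 4 estimated at a 2.5-fold higher number from compound 2 to compound 4 (0.40 log units; beyond the scatter). For compound 4 the expected value in this assay is 35000 nM, with a range from 10000 nM to 120000 nM.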

Compound 4, half-maximal inhibitory concentration: 47800 nM
Beside the measured number, compound 4's estimate is 1.4-fold (0.14 log units) below it; measured number inside the range.
By their numbers in this assay, from the lowest: compound 2; then compounds 4, 1 and 3 (each within the scatter of the next).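

In this assay, cyano in place of dimethylamino on an aromatic carbon para to a large group gives a 3.4-fold higher number from compound 2 to compound 4 (0.53 log units; beyond the scatter) with the rest of the molecule unchanged. Within the data shown here, this is the first single-place change, and it shows that the group at this position matters: the step lies beyond the scatter, and the dimethylamino compound gives the lower number of the pair. No measurement shown here bears on why the number moves with this exchange. Going by these compounds, what remains open is how other groups at this position would fare, such as a diethylamino group, a primary amine or a carboxylic acid. On these data alone, it is also open whether a group at this position other than dimethylamino could give a number as low as that of compound 2 or lower.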